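The compounds below may be only part of what the source reports. "The series", "measured", "known", "first", "only" and "open" are said of these compounds alone.

The measured compounds:

compound 1, `Nc1nc(Cl)c2ncn(Cc3ccc(CCl)cc3)c2n1`, > 100000 nM
compound 2, `ClCc1cccc(Cn2cnc3c(Cl)nc(Cl)nc32)c1`, 6910 nM
compound 3, `ClCc1ccc(Cn2cnc3c(Cl)nc(Cl)nc32)cc1`, 8320 nM

Three compounds were tested in a functional assay on LOX IMVI cells (Homo sapiens) for cytotoxicity, read by sulforhodamine B assay, with a stated time of 48 h; on this read-out lower numbers stand for higher toxicity in this test and higher numbers for lower toxicity in this test. Compound 2 gives 6910 nM, and compound 3 gives 8320 nM; the two numbers lie within the usual scatter of each other, so no order between them is claimed. The two share the same atoms joined differently, and the difference between the two cores is not broken down here.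

For compound 1 the result is a limit of the assay rather than a number, > 100000 nM. The change from compound 3 to compound 1 is amino in place of chloro on an aromatic carbon, and it brings an at least 12-fold higher number from compound 3 to compound 1 (1.07 log units; beyond the scatter). That the step is only known as a lower bound follows from the limit of > 100000 nM in this assay, at which 1 of the 3 values shown sits.

Compound 4, `Nc1nc(Cl)c2ncn(Cc3cccc(CCl)c3)c2n1`, has not yet been measured in this assay. It differs from compound 2 by amino in place of chloro on an aromatic carbon, the same change as that from compound 3 to compound 1, at a place described in the same words. Since compound 2 and compound 3 sit within the scatter of each other, the earlier step is taken as the guide: compound 4 is expected to show a 13-fold higher number from compound 2 to compound 4 (1.11 log units; beyond the scatter), resting on an at least 12-fold higher number from compound 3 to compound 1 (1.07 log units; beyond the scatter). The estimate for compound 4 is therefore 90000 nM, with a likely range from 30000 nM to 300000 nM, and a considerable chance that this assay again reports only a limit.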

Compound 4, concentration lethal to 50% of the cells: 81300 nM
The estimate for compound 4 lay 1.1-fold (0.04 log units) above the measured number, within the range that was stated.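

In this assay, amino in place of chloro on an aromatic carbon gives a 12-fold higher number from compound 2 to compound 4 (1.07 log units; beyond the scatter), so on this second core the change again goes with a higher number and lower toxicity in this test, and the step lies beyond the scatter. Set beside the earlier step, the two cases read as follows: the same change on two cores in this assay, an at least 12-fold higher number (1.07 log units; beyond the scatter) from compound 3 to compound 1 and a 12-fold higher number (1.07 log units; beyond the scatter) from compound 2 to compound 4; the limit leaves it open whether they differ. Going by these compounds, the two cores thus agree in direction, but the earlier step rests on a limit, so its true size is unknown and the data do not show that the change has the same size on both cores, nor do two cores establish a rule for the wider series: the limit of > 100000 nM in this assay, at which 1 of the 4 values shown sits.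

The compounds shown compare only amino and chloro at this carbon, which leaves open how a methoxy group, a methylamino group or a plain hydrogen there would read in this assay. On these data alone, all of them also carry a chloromethyl group, so it remains open whether the step would persist if a hydroxymethyl or methyl group stood in its place, or whether it would appear at all in cells other than those used here.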